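Swapping a pyridine acid for a benzoic acid on the azetidine

The source may hold more compounds than are shown below. What is called first, only, known or untested is meant among the compounds shown, and "the series" means these compounds.

Of the compounds shown here, three sharing one large core have been tested in an assay on isolated protein for agonist activity at Bile acid receptor (Homo sapiens), read by FRET; a higher number here means that more compound is needed for the effect, a lower number that less compound is needed. Compound 1 `CC(C)n1nc(C(=O)O)cc1[C@@H]1C[C@H]1c1ccc(OCc2c(-c3c(Cl)cccc3Cl)noc2C2CC2)cc1Cl` gives 4 nM in this assay. Compound 2 `O=C(O)c1cncc(N2CC(O)(c3ccc(OCc4c(-c5c(Cl)cccc5Cl)noc4C4CC4)cc3Cl)C2)c1` gives 7 nM in this assay, the second highest of the three numbers; its gap to compound 1 lies within the usual scatter, so the two cannot be told apart, while compound 3 `O=C(O)c1cccc([C@H]2C[C@@H](c3ccc(OCc4c(-c5c(Cl)cccc5Cl)noc4C4CC4)cc3Cl)C2)c1` gives 77 nM in this assay, a number well beyond the scatter above compound 2.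

Compound 4 `O=C(O)c1cccc(N2CC(O)(c3ccc(OCc4c(-c5c(Cl)cccc5Cl)noc4C4CC4)cc3Cl)C2)c1` has not yet been measured. It differs from compound 2 in one place: 3-carboxyphenyl in place of 5-carboxypyridin-3-yl on an amine nitrogen in a ring. The change trades one six-membered aromatic ring bearing a carboxylic acid for another; the ring with one nitrogen leaves and a ring of carbon only enters, on the amine nitrogen of the four-membered ring.

Among the measured compounds shown here, no measured pair shows this exact swap, so the expected size of the step rests on the spread seen among compound 1, compound 2 and compound 3, where the acid-bearing groups vary widely yet most numbers stay low. A small rise in the number is expected, close to the scatter, as the step of a 2.1-fold higher number from compound 2 to compound 4 (0.33 log units; beyond the scatter). Compound 4 is therefore expected to give about 15 nM in this assay, with a plausible range from 5 nM to 45 nM.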

Compound 4, half-maximal effective concentration: 54 nM
Compound 4: the middle estimate sits 3.6-fold (0.56 log units) below what was measured; measured number outside the range, above it.
By their numbers in this assay, from the lowest: compounds 1 and 2 (each within the scatter of the next); then compounds 4 and 3 (each within the scatter of the next).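

In this assay, among the compounds shown here, the step from one acid-bearing ring to the other is a 7.7-fold higher number from compound 2 to compound 4 (0.89 log units; beyond the scatter), the first direct reading of a change at this position on the amine nitrogen of the four-membered ring. For the compounds shown here, the two groups have the same number of heavy atoms and both carry the carboxylic acid, and the computed differences are a ring nitrogen exchanged for a ring carbon and one hydrogen-bond acceptor fewer, so this small exchange alone is enough to move the number beyond the scatter, something the earlier compounds, which differ in more than one place, could not isolate. No measurement here explains why the ring nitrogen matters in this way.

On these data alone, it remains open whether the same exchange would have a similar effect in another setting, such as a 3-carboxyphenyl group carrying a fluorine or a methoxy group, or on the core of compound 3. Whether the carboxylic acid itself is needed at this position is also unsettled, as the compounds shown offer no comparison with an amide or a tetrazole in its place.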